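Hydroxy for Ethyl: What Compound 4 Might Show

This account rests on a few compounds, and the source may have more. Where it says the series, first, only, none or still open, it means among the compounds named here.

Three compounds have been tested in a functional assay on the whole organism (Tail, strain ICR) with Mus musculus as the target, in the tail flick test, with a stated time of 120 min, at a dose of 25 umol/kg by the oral route; on this read-out lower numbers stand for a weaker effect and higher numbers for a stronger effect at the one dose given:

compound 1, `CC[C@H](C)[C@H](NC(=O)CN(c1nc(Cl)nc2[nH]cnc12)C1CC1)C(=O)OCc1ccccc1`, giving 22%
compound 2, `NC(=O)CC[C@H](NC(=O)CN(c1ncnc2c1ncn2C1CCCCO1)C1CC1)C(=O)OCc1ccccc1`, giving 22.3%
compound 3, `N=C(N)NCCC[C@H](NC(=O)CN(c1nc(Cl)nc2[nH]cnc12)C1CC1)C(=O)O`, giving 17%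

Compound 1 sits between the other two on these numbers: its nearest neighbour is compound 2, whose number lies a little higher, and its furthest is compound 3, whose number lies somewhat lower, yet both gaps fall within the usual scatter of this kind of measurement, so the three compounds cannot be told apart on this read-out.

Compound 4, `C[C@@H](O)[C@H](NC(=O)CN(c1nc(Cl)nc2[nH]cnc12)C1CC1)C(=O)OCc1ccccc1`, is the next compound to be tested. It differs from compound 1 in one place: hydroxy in place of ethyl on a saturated chain carbon bound to two saturated chain carbons. Within the data shown here, no pair of measured compounds shares this change, so nothing already seen indicates how it plays out in this assay. Since all three measured numbers sit so close together, the step from compound 1 to compound 4 is expected to stay within the scatter, a number 2 percentage points lower from compound 1 to compound 4 (within the scatter). Compound 4 is therefore estimated to give 20% in this assay, in a range from 8% to 34%.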

Compound 4, a percentage reported as activity, at one dose (the size of the read-out at that dose, not a potency): 30.7%
Estimate against measurement, compound 4: 10.7 percentage points below; the measured number falls inside the stated range.
By their numbers in this assay, from the lowest: compounds 3, 1, 2 and 4 (each within the scatter of the next, the first and the last beyond it).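

In this assay, among these compounds, hydroxy in place of ethyl on a saturated chain carbon bound to two saturated chain carbons gives a number 8.7 percentage points higher from compound 1 to compound 4 (within the scatter), the first reading of a single change, and it shows that this read-out does not separate sec-butyl from 1-hydroxyethyl. The exchange removes two carbons and adds one oxygen with its hydrogen-bond donor and acceptor, and the effect at this dose stays within the scatter of the parent's. Nothing measured here speaks to the reason for this outcome.

From the compounds shown here alone, whether an amine, a carboxylic acid or a longer chain at this place would read any differently remains open. Also open, going by these compounds, is whether the same exchange would read alike with the core of compound 2 in place of the core of compound 1.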